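A Dimethylamino Group Takes the Place of Chlorine

The source may report more compounds than this note shows. Statements on the series, on what has been measured and on what is new or still open speak of the compounds shown alone.

Compound 1, `O=C(N/N=C/c1ccc(Cl)cc1)c1cccnc1Nc1cccc(C(F)(F)F)c1`: 67.2%
Compound 2, `O=C(N/N=C/c1ccc(O)c(O)c1)c1cccnc1Nc1cccc(C(F)(F)F)c1`: 50.8%
Compound 3, `COc1cccc(/C=N/NC(=O)c2cccnc2Nc2cccc(C(F)(F)F)c2)c1`: 58.8%

These three share one core and differ only in the aryl group on a carbon with a double bond to nitrogen. In a functional assay on the whole organism (strain Wistar) for inhibition, with Rattus norvegicus as the target, read by paw edema, with a stated time of 1 h, at a dose of 10 mg/kg by the intraperitoneal route (on this read-out lower numbers stand for less inhibition and higher numbers for more inhibition at the one dose given (going by the name of the read-out)), compound 1 stands highest of the three numbers; its nearest neighbour is compound 3, and the change a number 8.4 percentage points lower from compound 1 to compound 3 (within the scatter) lies within the scatter, while a number 16.4 percentage points lower from compound 1 to compound 2 (beyond the scatter) lies beyond it. The two remaining compounds differ from each other by a number 8 percentage points higher from compound 2 to compound 3 (within the scatter).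

Compound 4, `CN(C)c1ccc(/C=N/NC(=O)c2cccnc2Nc2cccc(C(F)(F)F)c2)cc1`, follows the step from compound 1 in which (dimethylamino in place of chloro on an aromatic carbon). Both measured steps away from compound 1 point downward, one within and one beyond the scatter, so a modest fall in this assay is expected, though a result within the scatter of compound 1 would not surprise. The expected step is a number 9.2 percentage points lower from compound 1 to compound 4 (within the scatter). For compound 4 the estimate is 58%, between 44% and 70%.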

Compound 4, a percentage reported as inhibition, in the whole organism at one dose (the size of the read-out at that dose, not a potency): 63.5%
For compound 4 the middle estimate is 5.5 percentage points below the measured one; the range from low to high includes it.
By their numbers in this assay, from the lowest: compounds 2, 3, 4 and 1 (each within the scatter of the next, the first and the last beyond it).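

Chloro gives way to dimethylamino, three heavy atoms and a hydrogen-bond acceptor in place of one chlorine, and the step in this assay is a number 3.7 percentage points lower from compound 1 to compound 4 (within the scatter), so this change on the aromatic carbon para to a large group leaves no step beyond the scatter. Two more steps place the new compound among the others: a number 4.7 percentage points higher from compound 3 to compound 4 (within the scatter) and a number 12.7 percentage points higher from compound 2 to compound 4 (beyond the scatter), which sets compound 2 apart from compound 4 as it is from compound 1, while compound 3 stays within the scatter of all three. Nothing available here accounts for these numbers.

Going by these compounds, whether a plain amino group, a carboxylic acid or a longer chain such as diethylamino would hold the number at this position stays open. The single dose also leaves open how these compounds compare in potency.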